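This account rests on a few compounds, and the source may have more. Where it says the series, first, only, none or still open, it means among the compounds named here.

Three compounds share one core and were compared in an in vitro assay on LLC-PK1 cells for displacement of a labelled ligand from growth hormone secretagogue receptor type 1 (Homo sapiens); on this read-out higher numbers stand for weaker inhibition and lower numbers for stronger inhibition. Compound 1, `COc1ccc(-n2c(CCc3ccccc3)nnc2[C@H](NC(=O)c2ccccn2)c2c[nH]c3ccccc23)c(OC)c1`, gives 33 nM. Compound 2, `CCc1ccc(Cn2c(CCc3ccccc3)nnc2[C@H](NC(=O)c2ccccn2)c2c[nH]c3ccccc23)cc1`, gives 67 nM. Compound 3, `COc1ccc(Cn2c(CCc3ccccc3)nnc2[C@H](NC(=O)c2ccccn2)c2c[nH]c3ccccc23)cc1`, gives 0.7 nM, the lowest of the three numbers, and both of its steps to the others stand well beyond the scatter: a 47-fold lower number from compound 1 to compound 3 (1.67 log units; beyond the scatter), and a 96-fold lower number from compound 2 to compound 3 (1.98 log units; beyond the scatter). The step between the two weaker compounds was only modest: a 2.0-fold higher number from compound 1 to compound 2 (0.31 log units; beyond the scatter).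

Compound 4, `O=C(N[C@H](c1c[nH]c2ccccc12)c1nnc(CCc2ccccc2)n1-c1ccccc1)c1ccccn1`, differs from compound 3 in one place: phenyl in place of 4-methoxybenzyl on an aromatic nitrogen. Two of the measured steps bear on this change. The replacement of a benzyl group by a ring joined directly to the aromatic nitrogen was seen with a strongly higher number in this assay (a 47-fold lower number from compound 1 to compound 3 (1.67 log units; beyond the scatter) read in reverse), and the loss of the methoxy group from that ring was seen with a still larger rise (a 96-fold lower number from compound 2 to compound 3 (1.98 log units; beyond the scatter) read in reverse). Compound 4 loses both the extra carbon of the benzyl group and the methoxy group, so a large step towards a higher number is expected, an 86-fold higher number from compound 3 to compound 4 (1.93 log units; beyond the scatter). Compound 4 is therefore estimated at 60 nM in this assay, with a plausible range from 12 nM to 300 nM.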

Compound 4, half-maximal inhibitory concentration: 105 nM
The estimate for compound 4 lay 1.8-fold (0.24 log units) below the measured number, within the range that was stated.
By their numbers in this assay, from the lowest: compound 3; then compound 1; then compounds 2 and 4 (each within the scatter of the next).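

In this assay, this position tolerates very little change: phenyl on the aromatic nitrogen gives the largest step in the set (a 150-fold higher number from compound 3 to compound 4 (2.18 log units; beyond the scatter)), so the low number of compound 3 is lost entirely when 4-methoxybenzyl is cut back to the bare ring. Compound 4 sits much closer to the other two, with only scatter-sized separation from the ethyl-bearing benzyl (a 1.6-fold higher number from compound 2 to compound 4 (0.20 log units; within the scatter)) and a modest step from the dimethoxy-substituted ring (a 3.2-fold higher number from compound 1 to compound 4 (0.50 log units; beyond the scatter)). Of the four groups, then, only 4-methoxybenzyl stands apart, while a benzyl link with ethyl in compound 2 and two methoxy groups on a directly attached ring in compound 1 both leave the number far from that of compound 3.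

Plain benzyl and 4-methoxyphenyl would be needed to separate what the methoxy group and the extra carbon each contribute, and a longer chain such as 2-phenylethyl would show whether the ring can sit further from the nitrogen. No supporting evidence is available to explain why these groups differ so sharply.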